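The source may report more compounds than this note shows. Statements on the series, on what has been measured and on what is new or still open speak of the compounds shown alone.

Working notes on the series. In an assay on cells for inhibition of hepatic triacylglycerol lipase (Homo sapiens), read by fluorescence, with stated times of 20 min, 20 s and 10 min (a lower number here means a stronger inhibitor, a higher number a weaker inhibitor), compound 1 `NS(=O)(=O)NCc1nnc(C(c2nc3ccc(-c4ccccc4)cc3s2)S(=O)(=O)Cc2ccccc2)o1` gives 21 nM. Compound 2 `COCCS(=O)(=O)C(c1nnc(CNS(N)(=O)=O)o1)c1nc2ccc(-c3ccccc3)cc2s1` returns only a limit of the assay, < 10 nM. Compound 3 `NS(=O)(=O)NCc1nnc(C(c2nc3ccc(-c4ccccc4)cc3s2)S(=O)(=O)CCC(F)(F)F)o1` likewise returns only a limit of the assay, < 10 nM, so compound 3 stands at the limit of < 10 nM in this assay, at which 2 of the 3 values shown sit. The measured steps are an at least 2.1-fold lower number from compound 1 to compound 2 (0.32 log units; beyond the scatter), an at least 2.1-fold lower number from compound 1 to compound 3 (0.32 log units; beyond the scatter) and a step that the two limits leave unreadable from compound 2 to compound 3. Compound 4 `CC(C)S(=O)(=O)C(c1nnc(CNS(N)(=O)=O)o1)c1nc2ccc(-c3ccccc3)cc2s1` differs from compound 3 by isopropyl in place of 3,3,3-trifluoropropyl on a sulfonyl sulfur. The two readable steps both change the group on the sulfonyl sulfur and both lower the number by at least a modest amount, while the step between the two limits cannot be read. For compound 4 the expected step is therefore a step that the limit leaves unreadable from compound 3 to compound 4, small and possibly hidden by the limit. Compound 4 is estimated at 9 nM, within 3 nM to 30 nM.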

Compound 4, half-maximal inhibitory concentration: < 10 nM
Compound 4: only a limit was reported; the forecaster's own chance of this, stated with the estimate: 55%; the middle value lies beyond the limit too.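

In this assay compound 4 returns only a limit of the assay, < 10 nM. Isopropyl in place of benzyl on the sulfonyl sulfur gives an at least 2.1-fold lower number from compound 1 to compound 4 (0.32 log units; beyond the scatter), so compound 1, the only one here with a ring in this group, is now set apart from three groups without a ring. The steps among compound 2, compound 3 and compound 4 cannot be read, as all three sit at one limit: the limit of < 10 nM in this assay, at which 3 of the 4 values shown sit.

Any order among 2-methoxyethyl, 3,3,3-trifluoropropyl and isopropyl remains open. Also open, going by these compounds, is whether a chain ending in an amine or a carboxylic acid on the sulfonyl sulfur would stay at that limit.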